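The compounds below may be only part of what the source reports. "The series", "measured", "known", "first", "only" and "open" are said of these compounds alone.

Measured compounds:
- compound 1, `Cc1cc(C)c2sc(NC(=O)c3ccc(C(F)(F)F)cc3)nc2c1`, a functional assay on MDA-MB-231 cells (Homo sapiens) for antiproliferative activity, read by sulforhodamine B assay; a lower number here means a stronger inhibitor of growth, a higher number a weaker inhibitor of growth: 0.45 ug/mL
- compound 2, `Cc1ccc(C(=O)Nc2nc3cc(C)cc(C)c3s2)cc1`, this assay: 0.44 ug/mL
- compound 3, `O=C(Nc1ccccc1)Nc1nc2ccc(F)cc2s1`, this assay: > 10 ug/mL

Compound 2 and compound 1 share the same core and differ only in the group on the benzamide ring. In this assay compound 2 gives 0.44 ug/mL and compound 1 gives 0.45 ug/mL, so the two values sit within the scatter of each other, and a 1.0-fold lower number from compound 1 to compound 2 (0.01 log units; within the scatter). Compound 3 has a different core and a urea linker in place of the amide; its result in this assay is only a limit, (the limit of > 10 ug/mL in this assay, at which 1 of the 3 values shown sits), and it gives no number.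

The next compound, compound 4, is `Cc1cc(C)c2sc(NC(=O)c3ccc(C#N)cc3)nc2c1`. It keeps the core of compound 2 and changes the group on the benzamide ring: cyano in place of methyl on an aromatic carbon.

For the measured compounds named here, only one measured step bears on this change, the one from compound 1 to compound 2, and it stayed within the scatter. The group at that position was swapped once already without any change beyond the scatter, so for the cyano group a step no larger than the scatter is expected in this assay, in either direction. Compound 4 is therefore expected to give about 0.5 ug/mL, within 0.2 ug/mL to 1.5 ug/mL, which means an estimated step of a 1.1-fold higher number from compound 2 to compound 4 (0.06 log units; within the scatter).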

Compound 4, concentration for 50% growth inhibition: 0.48 ug/mL
For compound 4 the middle estimate is 1.0-fold (0.02 log units) above the measured one; the range from low to high includes it.
By their numbers in this assay, from the lowest: compounds 2, 1 and 4 (each within the scatter of the next). At a limit, above all of these: compound 3.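

In this assay this position has now carried three different groups, and cyano joins methyl and trifluoromethyl with all three values within the scatter of each other: the step is a 1.1-fold higher number from compound 2 to compound 4 (0.04 log units; within the scatter) and, measured against trifluoromethyl, a 1.1-fold higher number from compound 1 to compound 4 (0.03 log units; within the scatter). Until now a single swap was the only evidence, whereas cyano brings a nitrogen, a triple bond and a hydrogen-bond acceptor that methyl lacks, and the number in this assay still stays level, so among these three compounds growth inhibition does not follow the identity of the group at this position. Nothing measured here explains why these three groups give values so close together.

On these data alone, an amine, a carboxylic acid or a longer chain at this position could still behave differently, so how far this tolerance extends remains open. Compound 3 differs from the others in more than one place and its result is only a limit, so the effect of the urea linker alone, or of the other core, cannot be read from it.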